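Methoxy in place of chloro: expectation for compound 3

The source may hold more compounds than are shown below. What is called first, only, known or untested is meant among the compounds shown, and "the series" means these compounds.

Measured compounds:
compound 1, `O=C(NCc1cn(Cc2ccc(Cl)cc2)nn1)c1cn(-c2ccccc2)nc1-c1ccc(F)cc1`, 280 nM
compound 2, `O=C(NCc1cn(Cc2ccc(Cl)cc2)nn1)c1cn(-c2ccccc2)nc1-c1ccc(Cl)cc1`, 410 nM

In a functional assay on MIA PaCa-2 cells (Homo sapiens) for antiproliferative activity, read by sulforhodamine B assay, with a stated time of 48 h (on this read-out higher numbers stand for weaker inhibition of growth and lower numbers for stronger inhibition of growth), compound 1 gives 280 nM and compound 2 gives 410 nM. For the measured compounds named here, the single measured step, a 1.5-fold higher number from compound 1 to compound 2 (0.17 log units; within the scatter), leaves compound 2 level with compound 1 within the scatter. Compound 3 `COc1ccc(-c2nn(-c3ccccc3)cc2C(=O)NCc2cn(Cc3ccc(Cl)cc3)nn2)cc1` differs from compound 2 by methoxy in place of chloro on an aromatic carbon. Going by the values given here, no measured step covers a methoxy entering; the one step at this position, a 1.5-fold higher number from compound 1 to compound 2 (0.17 log units; within the scatter), stayed within the scatter, so no step beyond the scatter is expected in this assay, the estimated step being a 1.1-fold higher number from compound 2 to compound 3 (0.04 log units; within the scatter). Compound 3 is therefore expected to give 450 nM in this assay, estimated between 180 nM and 1100 nM.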

Compound 3, concentration for 50% growth inhibition: 26300 nM
Estimate against measurement, compound 3: 58-fold (1.77 log units) below; the whole stated range lies below it.
By their numbers in this assay, from the lowest: compounds 1 and 2 (each within the scatter of the next); then compound 3.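

Methoxy at this position gives a 64-fold higher number from compound 2 to compound 3 (1.81 log units; beyond the scatter) and a 94-fold higher number from compound 1 to compound 3 (1.97 log units; beyond the scatter) in this assay, so the position that tolerated the swap between the two halogens is not indifferent to every group. Among these three compounds, the 4-methoxyphenyl alone separates from the others, while compound 1 and compound 2 remain within the scatter of each other. Nothing at hand explains the size of this step and it stands as an observation only.

Going by these compounds, whether the loss is particular to methoxy remains open. A hydroxyl, an amine or the longer ethoxy at the same place would show how narrowly it is tied to this group.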